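A few compounds are considered here, and "the series" means these few. Any claim that something is new, unique, unknown or untested is made for them only; others in the source may bear on it.

Of the compounds shown here, two have so far been measured in a functional assay on HCT-116 cells (Homo sapiens) for inhibition, read by MTT assay, with a stated time of 72 h; on this read-out lower numbers stand for stronger inhibition of growth and higher numbers for weaker inhibition of growth. Compound 1 `O[C@H](COCCOC[C@@H](O)Cc1cn(Cc2cccc(-c3ccccc3)c2)nn1)Cc1ccc(-c2ccccc2)cc1` carries a 3-biphenylylmethyl group on the triazole nitrogen, and in this assay compound 1 gives 7200 nM. Compound 2 `O[C@H](COCCOC[C@@H](O)Cc1cn(-c2cncc3ccccc23)nn1)Cc1ccc(-c2ccccc2)cc1` carries an isoquinolin-4-yl group on that nitrogen instead, and in this assay compound 2 gives 17800 nM. Of the two numbers, that of compound 2 is the higher, and its gap to compound 1 lies beyond the scatter. Among the compounds with values here, no step between two measured compounds differing in one place is available, so the change leading to compound 3 `N#Cc1ccc(Cn2cc(C[C@H](O)COCCOC[C@@H](O)Cc3ccc(-c4ccccc4)cc3)nn2)cc1` cannot be tied to a measured step. Compound 3 is obtained from compound 2 by the change (4-cyanobenzyl in place of isoquinolin-4-yl on an aromatic nitrogen), that is, 4-cyanobenzyl in place of isoquinolin-4-yl on an aromatic nitrogen. Because compound 1, which likewise bears a benzyl-type group on that nitrogen, gives 7200 nM, compound 3 is expected to move toward compound 1, with an estimated step of a 2.0-fold lower number from compound 2 to compound 3 (0.30 log units; within the scatter) to a lower number in this assay. The estimate for compound 3 is 9000 nM, with a range from 3500 nM to 25000 nM.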

Compound 3, concentration for 50% growth inhibition: 8800 nM
For compound 3 the middle estimate is 1.0-fold (0.01 log units) above the measured one, within the range that was stated.
By their numbers in this assay, from the lowest: compounds 1 and 3 (each within the scatter of the next); then compound 2.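

In this assay, within the data shown here, the 4-cyanobenzyl group in place of isoquinolin-4-yl on the aromatic nitrogen gives a 2.0-fold lower number from compound 2 to compound 3 (0.31 log units; beyond the scatter), a modest step and the first measured change at this position. The second comparison, 4-cyanophenyl in place of 3-phenylphenyl on the saturated chain carbon bound to that aromatic nitrogen, gives a 1.2-fold higher number from compound 1 to compound 3 (0.09 log units; within the scatter), so these two groups cannot be told apart on this read-out, although one carries a nitrile and the other a further phenyl ring. Nothing at hand accounts for either step.

Going by these compounds, the step from compound 2 to compound 3 changes the ring and adds the saturated chain carbon at once, so the share of each in the difference remains open. Also open, on these data alone, are how a plain benzyl group, a carboxylic acid in place of the nitrile, or a longer chain between the ring and the aromatic nitrogen would read in this assay, and whether the same steps would hold with a different group at the far end of the shared core.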